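The source may hold more compounds than are shown below. What is called first, only, known or untested is meant among the compounds shown, and "the series" means these compounds.

In a functional assay on L02 cells (Homo sapiens) for inhibition, read by Griess assay, with stated times of 1 h and 24 h (a lower number here means a stronger inhibitor, a higher number a weaker inhibitor), compound 3 `Brc1ccc(Nc2nc(/C=C/c3ccccc3)nc3ccsc23)cc1` gives > 1000000 nM, which is a limit of the assay and not a number. Compound 1 `CC(C)CNc1nc(/C=C/c2ccccc2)nc2ccsc12` gives > 1000000 nM, also a limit. Compound 2 `CN1CCN(c2nc(/C=C/c3ccccc3)nc3ccsc23)CC1` gives a true number, 198000 nM. The picture so far is the limit of > 1000000 nM in this assay, at which 2 of the 3 values shown sit. Compound 4 `FC(F)(F)c1ccc(Nc2nc(/C=C/c3ccccc3)nc3ccsc23)cc1` changes one place of compound 3: trifluoromethyl in place of bromo on an aromatic carbon. The measured steps all alter the whole group on the core, and none tests this swap: there is an at least 5.0-fold lower number from compound 1 to compound 2 (0.70 log units; beyond the scatter), then an at least 5.0-fold higher number from compound 2 to compound 3 (0.70 log units; beyond the scatter), and also a step that the two limits leave unreadable from compound 1 to compound 3. Among the measured compounds shown here, with no measured step to suggest a direction, the expected result is a number no higher from compound 3 to compound 4 (the limit leaves the size open), so no change beyond the scatter is expected. For compound 4 the estimated value is 1000000 nM, with an expected range from 400000 nM to 2500000 nM.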

Compound 4, half-maximal inhibitory concentration: > 1000000 nM
Compound 4: only a limit was reported; the forecaster's own chance of this, stated with the estimate: 65%; the middle value sits exactly at the limit.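

Compound 3 and compound 4 both give only a limit of the assay, so the step between them cannot be read: the limit of > 1000000 nM in this assay, at which 3 of the 4 values shown sit. The compounds shown leave open whether trifluoromethyl in place of bromo changes inhibition at all.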